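From 3-fluoropropyl to 2-methoxyethyl on the shared core

The compounds below may be only part of what the source reports. "The series", "measured", "known", "first", "only" and "open" are said of these compounds alone.

In a physicochemical assay for lipophilicity, read by HPLC, at pH 7.4 (a lower number here means a more polar compound, a higher number a more lipophilic compound), compound 3 `Cc1ccccc1N1C(=O)/C(=C/c2ccc(O)c(Cl)c2)S/C1=N\CCCF` gives 3.4 and stands second highest of the three measured compounds. Compound 2 `CCC/N=C1\S/C(=C\c2ccc(O)c(C(C)C)c2)C(=O)N1c1ccccc1C` reads higher at 4.3 and compound 1 `Cc1ccccc1N1C(=O)/C(=C/c2ccc(O)c(Cl)c2)S/C1=N\CCO` reads lower at 1.9 with both gaps beyond the scatter.

Compound 4 `COCC/N=C1\S/C(=C\c2ccc(O)c(Cl)c2)C(=O)N1c1ccccc1C` is not yet measured. It carries methoxy in place of fluoromethyl on a saturated chain carbon, two bonds along the chain from a double-bonded nitrogen on a saturated chain carbon, two bonds along the chain from a double-bonded nitrogen.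

For the measured compounds named here, one measured step bears on this place: a number 1.50 log units higher from compound 1 to compound 3 (beyond the scatter) for fluoromethyl in place of hydroxy, a large step beyond the scatter. Going by the values given here, no measured compound carries methoxy, so this single step is the only guide. Compound 4 keeps an oxygen on the chain as compound 1 does, but without the hydroxy, so a moderate fall from compound 3 is expected, smaller than that large step yet beyond the scatter. The expected change is a number 0.50 log units lower from compound 3 to compound 4 (beyond the scatter) as an estimate. For compound 4 the estimated value is 2.9 with an expected range from 2.5 to 3.3 in this assay as the read-out.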

Compound 4, distribution coefficient: 2.9
Compound 4: middle estimate and measured number agree at the digits printed, and the stated range covers the measured number.
By their numbers in this assay, from the lowest: compound 1; then compound 4; then compound 3; then compound 2.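

Methyl in place of hydrogen on the chain oxygen gives a number 1.00 log units higher from compound 1 to compound 4 (beyond the scatter) in this assay, the first reading of this oxygen capped at this position. Methoxy in place of fluoromethyl gives a number 0.50 log units lower from compound 3 to compound 4 (beyond the scatter), so compound 4 divides a number 1.50 log units higher from compound 1 to compound 3 (beyond the scatter) into two steps, each beyond the scatter, and the three chain ends on this shared core now stand in the order hydroxy, methoxy, fluoromethyl from lowest to highest. No supporting data bear on why the steps take these sizes.

On these data alone, an amine or a carboxylic acid at the chain end, or a longer ether chain such as 3-methoxypropyl, remains open at this position. Also open, as far as these compounds go, is whether the same order holds with the isopropyl group of compound 2 in place of the chlorine on the shared core.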